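The source may report more compounds than this note shows. Statements on the series, on what has been measured and on what is new or still open speak of the compounds shown alone.

Three members of the series have been run in a toxicity assay on HepG2 2.2.15 cells (Homo sapiens) for cytotoxicity, read by CCK-8 assay, with a stated time of 8 days; a lower number here means that less compound is tolerated, a higher number that more compound is tolerated. Compound 1 `CC(C)Cc1nn(-c2nccs2)cc1C(=O)NCc1cccc(F)c1` gives > 100000 nM, which is a limit of the assay and not a number. Compound 2 `CC(C)Cc1nn(-c2nccs2)cc1C(=O)NCc1ccc(F)cc1F` gives 83600 nM. Compound 3 `CC(C)Cc1nn(-c2nccs2)cc1C(=O)NCc1ccc(F)cc1` gives > 100000 nM, again a limit of the assay rather than a number. Among the measured compounds shown here, compound 3 thus stands at the limit of > 100000 nM in this assay, at which 2 of the 3 values shown sit, and compound 2 carries the only value read as a number. The measured steps are small or unreadable: an at least 1.1-fold lower number from compound 1 to compound 2 (0.07 log units; that floor lies within the scatter), an at least 1.1-fold higher number from compound 2 to compound 3 (0.07 log units; that floor lies within the scatter), while a step that the two limits leave unreadable from compound 1 to compound 3.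

Compound 4 `CC(C)Cc1nn(-c2nccs2)cc1C(=O)NCc1ccc(N)cc1` has not yet been measured; it differs from compound 3 by amino in place of fluoro on an aromatic carbon. For the measured compounds named here, of the measured steps, only the change from compound 2 to compound 3 concerns a fluoro group on the aromatic ring, and that step stayed within the scatter; no measured step covers an amino group. In this assay compound 4 is therefore expected to show no step beyond the scatter, a number no higher from compound 3 to compound 4 (the limit leaves the size open). Compound 4 is estimated at 100000 nM, within 45000 nM to 220000 nM, with a fair chance that only a limit is reported.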

Compound 4, half-maximal cytotoxic concentration: > 100000 nM
Compound 4: only a limit was reported; the forecaster's own chance of this, stated with the estimate: 60%; the middle value lies on the limit itself.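

In this assay, compound 4 brings an amino group into the series, on the aromatic carbon para to a large group, and its result is a limit of the assay, not a number: the limit of > 100000 nM in this assay, at which 3 of the 4 values shown sit.

Among the compounds shown here, the one step that can be read is an at least 1.1-fold higher number from compound 2 to compound 4 (0.07 log units; that floor lies within the scatter), so the amino group gives no sign of a lower tolerated concentration than the 2,4-difluorophenyl compound. The steps that join compound 4 to compound 1 and compound 3 cannot be read.

As far as these compounds go, how far amino and fluoro differ on this carbon in this assay stays open, with both compounds at a limit. Also open, from the compounds shown here alone, is whether a carboxylic acid or a methoxy group on the same carbon would give a value that can be read as a number.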